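Changing the Aryl Group on the Triazole of Compound 2

The source may hold more compounds than are shown below. What is called first, only, known or untested is meant among the compounds shown, and "the series" means these compounds.

This series shares one core and differs only in the aryl group attached to an aromatic nitrogen of the triazole. Compound 1 `N#CC1=C(N)Oc2c(N)cc3nc4ccccc4nc3c2C12C(=O)N(Cc1cnnn1-c1ccc(Cl)cc1Cl)c1ccccc12` carries a 2,4-dichlorophenyl there. In an ADME assay on L02 cells (Homo sapiens) for antiproliferative activity, read by MTT assay, with a stated time of 48 h (on this read-out lower numbers stand for stronger inhibition and higher numbers for weaker inhibition), compound 1 returns > 50000 nM, which is a limit of the assay rather than a number. Compound 2 `COc1ccc(OC)c(-n2nncc2CN2C(=O)C3(C(C#N)=C(N)Oc4c(N)cc5nc6ccccc6nc5c43)c3ccccc32)c1` carries a 2,5-dimethoxyphenyl in the same place. In this assay compound 2 also returns > 50000 nM, again a limit. Within the data shown here, because both values sit at the limit of > 50000 nM in this assay, at which 2 of the 2 values shown sit, the step that the two limits leave unreadable from compound 1 to compound 2 cannot be read, and compound 2 stands only at a limit, as does the one other value shown. Compound 3 `N#CC1=C(N)Oc2c(N)cc3nc4ccccc4nc3c2C12C(=O)N(Cc1cnnn1-c1ccc(F)c(Cl)c1)c1ccccc12` differs from compound 2 by 3-chloro-4-fluorophenyl in place of 2,5-dimethoxyphenyl on an aromatic nitrogen. Among the measured compounds shown here, the only measured step on this position is unreadable, so it gives no direction and no size for the change to compound 3. With both neighbours at the limit, compound 3 is expected to remain there, with a step of a number no higher from compound 2 to compound 3 (the limit leaves the size open) meaning no change beyond the scatter. The estimate for compound 3 in this assay is 50000 nM, within a range from 20000 nM to 120000 nM.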

Compound 3, half-maximal inhibitory concentration: > 50000 nM
Compound 3: no number, only a limit (the forecaster's own chance of this, stated with the estimate: 80%); the middle value sits exactly at the limit.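

Compound 3 returns > 50000 nM, a limit of the assay and not a number. The steps linking compound 1, compound 2 and compound 3 therefore cannot be read: the limit of > 50000 nM in this assay, at which 3 of the 3 values shown sit. The compounds shown leave open whether these three aryl groups on the triazole differ at all in this assay.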